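Compound 3 to compound 4: a tolerated chain, extended

This account rests on a few compounds, and the source may have more. Where it says the series, first, only, none or still open, it means among the compounds named here.

Compound 1 `CCCCCCCC(=O)Nc1nc(N)nc2c1ncn2[C@H]1CO[C@@H](CO)O1`, compound 2 `CCCCCCCCCC(=O)Nc1nc(N)nc2c1ncn2[C@H]1CO[C@@H](CO)O1` and compound 3 `CCCCCCCCCCCCCCCC(=O)Nc1nc(N)nc2c1ncn2[C@H]1CO[C@@H](CO)O1` share one core and differ only in their saturated chain. In an ADME assay on Vero cells (Chlorocebus sabaeus) for cytotoxicity (a lower number here means that less compound is tolerated, a higher number that more compound is tolerated), compound 1 gives > 100000 nM, which is a limit of the assay. Compound 2 gives > 100000 nM, again a limit. Within the data shown here, compound 3 gives 90000 nM, the only actual number in the set.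

Compound 4 `CCCCCCCC/C=C\CCCCCCCC(=O)Nc1nc(N)nc2c1ncn2[C@H]1CO[C@@H](CO)O1` differs from compound 3 as follows: dec-1-en-1-yl in place of octyl on a saturated chain carbon, seven bonds along the chain from a carbonyl carbon. In words, dec-1-en-1-yl stands in place of octyl on a saturated chain carbon, seven bonds along the chain from a carbonyl carbon.

The closest evidence is the earlier variation of the same chain. It gave an at least 1.1-fold lower number from compound 1 to compound 3 (0.04 log units; that floor lies within the scatter). It also gave an at least 1.1-fold lower number from compound 2 to compound 3 (0.04 log units; that floor lies within the scatter). The remaining measured step is a step that the two limits leave unreadable from compound 1 to compound 2 and adds nothing on size. Among the measured compounds shown here, no measured compound carries a double bond, so that part of the change has no direct precedent. No step beyond the scatter is therefore expected in this assay, and the assay may again report only a limit. The step expected is a 1.1-fold lower number from compound 3 to compound 4 (0.02 log units; within the scatter). The estimate for compound 4 is 85000 nM, with an expected range of 40000 nM to 120000 nM.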

Compound 4, half-maximal cytotoxic concentration: 19000 nM
For compound 4 the middle estimate is 4.5-fold (0.65 log units) above the measured one; the whole stated range lies above it.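

In this assay, this saturated chain carbon, seven bonds along the chain from a carbonyl carbon, now yields a step that can be read at full size: dec-1-en-1-yl in place of octyl gives a 4.7-fold lower number from compound 3 to compound 4 (0.68 log units; beyond the scatter). The earlier chain variation showed no step beyond the scatter, whereas compound 4 separates from each of the other three compounds, so a change at this position can alter the number in this assay. Against the two shorter chains the record reads an at least 5.2-fold lower number from compound 2 to compound 4 (0.72 log units; beyond the scatter) and an at least 5.2-fold lower number from compound 1 to compound 4 (0.72 log units; beyond the scatter), and both sizes are only floors because the values of compound 1 and compound 2 are limits:the limit of > 100000 nM in this assay, at which 2 of the 4 values shown sit.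

The step to compound 4 brings in the extra carbons and the double bond together, so the compounds shown do not tell which of the two accounts for the lower number; decyl at this place, with no double bond, would separate them. Also open, as far as these compounds go, are whether the geometry of the double bond matters, as a trans dec-1-en-1-yl would show, and whether a carboxylic acid or an amine at the chain end would keep the step.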